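This account rests on a few compounds, and the source may have more. Where it says the series, first, only, none or still open, it means among the compounds named here.

Measured compounds:

Compound 1, `O=C(Nc1cccc(-n2cc(-c3ccncc3)c(-c3ccc(Cl)c(O)c3)n2)c1)Nc1cccc(C(F)(F)F)c1`, gives 1180 nM in a functional assay on NCI-H460 cells (Homo sapiens) for inhibition, read by sulforhodamine B assay, with a stated time of 48 h; on this read-out lower numbers stand for stronger inhibition of growth and higher numbers for weaker inhibition of growth.
Compound 2, `COc1cc(-c2nn(-c3cccc(NC(=O)Nc4cc(C(F)(F)F)cc(C(F)(F)F)c4)c3)cc2-c2ccncc2)ccc1Cl`, gives 558 nM.
Compound 3, `COc1cc(-c2nn(-c3cccc(NC(=O)Nc4cccc(C(F)(F)F)c4)c3)cc2-c2ccncc2)ccc1Cl`, gives 763 nM.

All three share one core and differ only in small substituents at the edges. Compound 3 holds the second highest of the three numbers; its nearest neighbour is compound 2, its furthest compound 1, and both of those gaps are within the usual scatter of the assay.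

Compound 4, `COc1cc(-c2nn(-c3cccc(NC(=O)Nc4ccc(Cl)c(C(F)(F)F)c4)c3)cc2-c2ccncc2)ccc1Cl`, is built from compound 3 by one change: chloro in place of hydrogen on an aromatic carbon. The measured step that bears most directly on this is the one on the same terminal ring, where a substituent was removed: a 1.4-fold higher number from compound 2 to compound 3 (0.14 log units; within the scatter). The other step, a 1.5-fold lower number from compound 1 to compound 3 (0.19 log units; within the scatter), concerns a different part of the molecule and is also within the scatter. Adding a small substituent to the same ring is therefore expected to give at most a small shift toward a lower number, a 1.3-fold lower number from compound 3 to compound 4 (0.10 log units; within the scatter), nothing beyond the scatter with confidence. For compound 4 the expected value is 600 nM, with a likely range from 250 nM to 1500 nM.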

Compound 4, concentration for 50% growth inhibition: 1110 nM
Compound 4: the middle estimate sits 1.9-fold (0.27 log units) below what was measured, within the range that was stated.
By their numbers in this assay, from the lowest: compounds 2, 3, 4 and 1 (each within the scatter of the next, the first and the last beyond it).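

In this assay, placing chloro on the terminal ring of compound 3, ortho to the trifluoromethyl group and para to the large group that joins this ring to the rest of the molecule, gives a 1.5-fold higher number from compound 3 to compound 4 (0.16 log units; within the scatter). This shows that this previously unsubstituted position can carry a chloro without moving the number beyond the scatter, just as the other substitution on this ring stays within it, a 1.4-fold higher number from compound 2 to compound 3 (0.14 log units; within the scatter). No measurement here offers an explanation for the step.

As far as these compounds go, it remains open whether a different group at this position, such as an amine, a carboxylic acid or a longer chain, would move the number beyond the scatter. From the compounds shown here alone, it is also open whether the same chloro step would read alike on the hydroxy-bearing core of compound 1.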